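The source may report more compounds than this note shows. Statements on the series, on what has been measured and on what is new or still open speak of the compounds shown alone.

Three compounds share one core and differ only in the group carried on an aromatic nitrogen. Compound 1 `N#CC1=C(N)Oc2c(c3nc4ccccc4nc3c3ccccc23)C12C(=O)N(Cc1cnnn1-c1cccc(Cl)c1)c1ccccc12` was tested in an ADME assay on HUVEC cells (Homo sapiens) for antiproliferative activity, read by MTT assay, with a stated time of 48 h; on this read-out higher numbers stand for weaker inhibition and lower numbers for stronger inhibition. In this assay compound 1 gives > 50000 nM, which is a limit of the assay and not a number. Compound 2 `COc1ccc(-n2nncc2CN2C(=O)C3(C(C#N)=C(N)Oc4c3c3nc5ccccc5nc3c3ccccc43)c3ccccc32)cc1` carries 4-methoxyphenyl in place of 3-chlorophenyl on that nitrogen. In this assay compound 2 gives > 50000 nM, again a limit. The step that the two limits leave unreadable from compound 1 to compound 2 therefore cannot be read; both its ends sit at the limit. Compound 3 `CC(=O)Nc1ccc(-n2nncc2CN2C(=O)C3(C(C#N)=C(N)Oc4c(N)cc5nc6ccccc6nc5c43)c3ccccc32)cc1` is the third member. In this assay compound 3 gives > 50000 nM, a limit as well. Compound 3 thus stands where the other two stand, at the limit of > 50000 nM in this assay, at which 3 of the 3 values shown sit. Compound 4 `N#CC1=C(N)Oc2c(N)cc3nc4ccccc4nc3c2C12C(=O)N(Cc1cnnn1-c1c(Cl)cc(Cl)cc1Cl)c1ccccc12` has not yet been measured. It differs from compound 3 in one place: 2,4,6-trichlorophenyl in place of 4-acetamidophenyl on an aromatic nitrogen. Among the measured compounds shown here, the only computed step among the measured compounds, a step that the two limits leave unreadable from compound 1 to compound 2, is unreadable, so no measured step gives a size or direction for exchanging the group on this nitrogen. Since every group tried so far leaves this assay at its limit, compound 4 is expected to show no step beyond the scatter, a number no higher from compound 3 to compound 4 (the limit leaves the size open). Compound 4 is expected to give 50000 nM in this assay, with a range from 20000 nM to 120000 nM and a high chance that only a limit is reported.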

Compound 4, half-maximal inhibitory concentration: 18300 nM
Beside the measured number, compound 4's estimate is 2.7-fold (0.44 log units) above it; the measured number lies below the stated range.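

In this assay, among the compounds shown here, the group on the aromatic nitrogen of the five-membered ring can change the read-out on the core of compound 3: 2,4,6-trichlorophenyl in place of 4-acetamidophenyl gives an at least 2.7-fold lower number from compound 3 to compound 4 (0.43 log units; beyond the scatter), whereas the only earlier step at this position, between compound 1 and compound 2, cannot be read. The start of this new step is a limit, so its direction is clear but its size is only a lower bound. Compound 4 is the only compound shown with a value that is a number and not a limit: the limit of > 50000 nM in this assay, at which 3 of the 4 values shown sit.

The step exchanges the whole group at once, so the compounds shown do not separate any contribution of the three chlorine atoms from that of losing the acetamide, and they do not show whether 2,4,6-trichlorophenyl would have the same effect on the core of compound 1. Also open, going by these compounds, is how this core would read with an unsubstituted phenyl, a phenyl carrying a single chlorine atom, or a phenyl carrying three bromine atoms on this nitrogen.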